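Swapping an Ethyl for Chlorine on a Sulfonate Ester Chain

The compounds below may be only part of what the source reports. "The series", "measured", "known", "first", "only" and "open" are said of these compounds alone.

Of the compounds shown here, three have so far been tested in a functional assay on HT-1080 cells (Homo sapiens) for antiproliferative activity, read by sulforhodamine B assay, with a stated time of 48 h; a higher number here means a weaker inhibitor, a lower number a stronger inhibitor. Compound 1, `CCCCCC(=O)Nc1ccc(S(=O)(=O)Oc2ccccc2I)cc1`, gives 9600 nM in this assay. Compound 2, `O=C(CCCCl)Nc1ccc(S(=O)(=O)Oc2ccccc2I)cc1`, gives 12000 nM in this assay. These two differ only by chloro in place of ethyl on a saturated chain carbon, three bonds along the chain from a carbonyl carbon, and that single change produced a 1.3-fold higher number from compound 1 to compound 2 (0.10 log units; within the scatter). Compound 3, `CCCCCNC(=O)Nc1ccc(S(=O)(=O)Oc2ccccc2C(C)C)cc1`, is built on a different core; how its core differs from that of compound 1 is not broken down here. In this assay compound 3 gives 4700 nM, the lowest of the three numbers, and its gap to each of compound 1 and compound 2 lies beyond the scatter.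

Compound 4, `CC(C)c1ccccc1OS(=O)(=O)c1ccc(NC(=O)NCCCCl)cc1`, has not yet been measured. It differs from compound 3 by chloro in place of ethyl on a saturated chain carbon, three bonds along the chain from an amide-type nitrogen. Among the compounds with values here, this is the same kind of change as the one from compound 1 to compound 2, but not the same: there the place was three bonds along the chain from a carbonyl carbon, here it is three bonds along the chain from an amide-type nitrogen. A step of similar, small size is expected for compound 4, a 1.3-fold higher number from compound 3 to compound 4 (0.11 log units; within the scatter), because the earlier example of this kind of change gave a 1.3-fold higher number from compound 1 to compound 2 (0.10 log units; within the scatter). Within the data shown here, only one such example exists, so the expectation is loose. Compound 4 is therefore estimated to give 6000 nM in this assay, with a likely range from 2500 nM to 15000 nM.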

Compound 4, half-maximal inhibitory concentration: 2700 nM
For compound 4 the middle estimate is 2.2-fold (0.35 log units) above the measured one, within the range that was stated.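

In this assay, chloro in place of ethyl on the chain gives a 1.7-fold lower number from compound 3 to compound 4 (0.24 log units; within the scatter), so on this core the swap leaves the number within the usual scatter of repeated measurements. The printed directions of the two steps are opposite, but each step is small, and the gap between them is no larger than two such steps can show by scatter alone; on these two cores, then, the change behaves alike, with no measurable effect on the number: the same change on two cores in this assay, a 1.3-fold higher number (0.10 log units; within the scatter) from compound 1 to compound 2 and a 1.7-fold lower number (0.24 log units; within the scatter) from compound 3 to compound 4, 2.2-fold (0.34 log units) apart, within the scatter of two such steps. This does not establish a rule for other cores, since it rests on two pairs, in which the swapped carbon sits in a different place, three bonds along the chain from a carbonyl carbon in one pair and from an amide-type nitrogen in the other, and steps this small cannot reveal whether chloro has a slight real effect or whether that effect differs between the cores.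

The compounds shown leave open whether a different group at the end of the chain, such as an amine, a hydroxyl group or a carboxylic acid, would shift the number beyond the scatter. They also leave open whether a longer chain carrying chloro at its end would behave as these shorter ones do.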